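Ring amine substituent: isopropyl to 4-fluorophenyl

The source may report more compounds than this note shows. Statements on the series, on what has been measured and on what is new or still open speak of the compounds shown alone.

Measured compounds in a functional assay on DU-145 cells (Homo sapiens) for cytotoxicity, read by sulforhodamine B assay, with a stated time of 48 h; a lower number here means a stronger inhibitor of growth, a higher number a weaker inhibitor of growth:
compound 1 `CC(C)N1CCN(c2nc(Nc3ccc(C#N)c(C(F)(F)F)c3)nc(Oc3ccnc4ccccc34)n2)CC1` — compound 1 gives > 100000 nM, a limit.
compound 2 `CCN1CCN(c2nc(Nc3ccc(C#N)c(C(F)(F)F)c3)nc(Oc3ccnc4ccccc34)n2)CC1` — compound 2 gives > 100000 nM, a limit.

Compound 1 stands only at a limit of this assay; what is known for compound 1 is the limit > 100000 nM and not a number. Going by the values given here, the one step measured so far, a step that the two limits leave unreadable from compound 1 to compound 2, sets hydrogen in place of methyl on a saturated chain carbon bound to the amine nitrogen in the ring and a saturated chain carbon; its size cannot be read because of the limit of > 100000 nM in this assay, at which 2 of the 2 values shown sit.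

Compound 3 `N#Cc1ccc(Nc2nc(Oc3ccnc4ccccc34)nc(N3CCN(c4ccc(F)cc4)CC3)n2)cc1C(F)(F)F` differs from compound 1 by 4-fluorophenyl in place of isopropyl on an amine nitrogen in a ring. Among the compounds with values here, no measured step replaces the group on the amine nitrogen in the ring with an aromatic group, so the measured steps give neither a size nor a direction for this assay here; all that the two measured compounds show is that both sit at the limit. Compound 3 is therefore expected to stay at or near that limit, with the step that the limit leaves unreadable from compound 1 to compound 3 expected to be no larger than the scatter. The estimate for compound 3 is 150000 nM, with a range from 30000 nM to 600000 nM.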

Compound 3, concentration for total growth inhibition: > 100000 nM
Compound 3 gave a limit, no number; the forecaster's own chance of this, stated with the estimate: 70%; the middle value does not contradict the limit.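

No new step can be read, since compound 1, compound 2 and compound 3 all stand at a limit and give no number: the limit of > 100000 nM in this assay, at which 3 of the 3 values shown sit.

The compounds shown leave open whether any group on the amine nitrogen in the ring gives a readable value in this assay, and how isopropyl, ethyl and 4-fluorophenyl would compare there.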